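This account rests on a few compounds, and the source may have more. Where it says the series, first, only, none or still open, it means among the compounds named here.

In a functional assay on MCF7 cells (Homo sapiens) for antiproliferative activity, read by MTT assay, with a stated time of 48 h (on this read-out higher numbers stand for weaker inhibition and lower numbers for stronger inhibition), compound 1 `c1ccc(-c2nn(-c3ccccc3)cc2-c2nc3ccccc3[nH]2)cc1` gives 3190 nM and compound 2 `Clc1ccc2[nH]c(-c3cn(-c4ccccc4)nc3-c3ccccc3)nc2c1` gives 1960 nM, two numbers within the scatter of each other. Compound 3 `Cc1ccc2[nH]c(-c3cn(-c4ccccc4)nc3-c3ccccc3)nc2c1` differs from compound 1 by methyl in place of hydrogen on an aromatic carbon. Going by the values given here, the one measured step that bears on this, chloro in place of hydrogen on an aromatic carbon, is a 1.6-fold lower number from compound 1 to compound 2 (0.21 log units; within the scatter), and no methyl compound has yet been measured. No step beyond the scatter is therefore expected in this assay, the estimated step being a 1.3-fold lower number from compound 1 to compound 3 (0.11 log units; within the scatter). For compound 3 the expected value is 2500 nM, with an estimated range of 1100 nM to 5500 nM.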

Compound 3, half-maximal inhibitory concentration: 5940 nM
For compound 3 the middle estimate is 2.4-fold (0.38 log units) below the measured one, outside the stated range (above it).
By their numbers in this assay, from the lowest: compounds 2, 1 and 3 (each within the scatter of the next, the first and the last beyond it).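

In this assay, methyl on this aromatic carbon gives a 1.9-fold higher number from compound 1 to compound 3 (0.27 log units; within the scatter) and so does not separate compound 3 from compound 1. Exchanging chloro for methyl on the same carbon gives a 3.0-fold higher number from compound 2 to compound 3 (0.48 log units; beyond the scatter) and is the only step shown that lies beyond the scatter, a modest one, so the two groups can be told apart here although neither can be told apart from hydrogen. Nothing available explains this difference.

The compounds shown leave open how a methoxy group, an amine or a carboxylic acid on this carbon would read. They also leave open whether chloro and methyl would differ in the same way on other carbons of this ring.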